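Trifluoromethyl for methoxycarbonyl: an expected cell tolerance

This account rests on a few compounds, and the source may have more. Where it says the series, first, only, none or still open, it means among the compounds named here.

Compound 1, `COC(=O)c1ccc(NC(=O)Nc2cc(C)nc3ccccc23)cc1`, gives 15000 nM in an ADME assay on HEK293 cells (Homo sapiens) for cytotoxicity, with a stated time of 72 h; on this read-out higher numbers stand for an effect only at larger amounts of compound and lower numbers for an effect already at smaller amounts.
Compound 2, `Cc1cc(NC(=O)Nc2cc(Cl)cc(Cl)c2)c2ccccc2n1`, reaches only the limit of > 25000 nM in this assay.
Compound 3, `COc1cccc(NC(=O)Nc2cc(C)nc3ccccc23)c1`, likewise sits at the limit of > 25000 nM in this assay.

Among the three measured ureas, compound 1 is the only one for which this assay returns an actual number; the other two stop at the limit of > 25000 nM in this assay, at which 2 of the 3 values shown sit, so no measured step within the set can be drawn. Compound 4, `Cc1cc(NC(=O)Nc2ccc(C(F)(F)F)cc2)c2ccccc2n1`, differs from compound 1 by trifluoromethyl in place of methoxycarbonyl on an aromatic carbon.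

Among the measured compounds shown here, since the set offers no step between measured compounds, any expectation for compound 4 rests on the value of compound 1 alone and on the fact that the remaining compounds lie at the limit. On that basis compound 4 is expected to show a step from compound 1 of about a 1.3-fold higher number from compound 1 to compound 4 (0.12 log units; within the scatter) in this assay, that is, little or nothing beyond the scatter, with a real chance that only a limit is reported. The estimate for compound 4 in this assay is therefore 20000 nM, within a range from 8000 nM to 40000 nM.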

Compound 4, half-maximal effective concentration: 25000 nM
The estimate for compound 4 lay 1.3-fold (0.10 log units) below the measured number; the range from low to high includes it.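

With compound 4 the set gains its first measured step: in this assay, trifluoromethyl in place of methoxycarbonyl, on an aromatic carbon para to a large group, gives a 1.7-fold higher number from compound 1 to compound 4 (0.22 log units; within the scatter). At this position, exchanging the carbonyl-bearing group for the fluorinated one does not shift the read-out beyond the scatter, so the value of compound 1 does not depend specifically on methoxycarbonyl. Compound 2 and compound 3 remain limits rather than numbers, so no steps to them can be read: the limit of > 25000 nM in this assay, at which 2 of the 4 values shown sit.

The compounds shown leave open whether a carboxylic acid or an amine at this same position would also stay within the scatter of compound 1. This single step also cannot show whether trifluoromethyl would give the same result elsewhere on the ring.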